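Replacing the 2-bromophenyl group of compound 3

The source may hold more compounds than are shown below. What is called first, only, known or untested is meant among the compounds shown, and "the series" means these compounds.

Compound 1 `COC(=O)/C=C/c1cccc(N(Cc2ccc(-c3c(OC)cccc3OC)cc2)C(=O)C2CCCCC2)c1` in an assay on isolated protein with Bile acid receptor (Homo sapiens) as the target; on this read-out lower numbers stand for an effect already at smaller amounts and higher numbers for an effect only at larger amounts of compound: compound 1 gives 77 nM.
Compound 2 `COC(=O)/C=C/c1cccc(N(C)C(=O)C2CCCCC2)c1`: compound 2 reaches only the assay limit, > 1000 nM.
Compound 3 `COC(=O)/C=C/c1cccc(N(Cc2ccccc2Br)C(=O)C2CCCCC2)c1`: compound 3 likewise reaches only the assay limit, > 1000 nM.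

Compound 3 thus stands at the limit rather than at a number, a position it shares with one other value (the limit of > 1000 nM in this assay, at which 2 of the 3 values shown sit). Among the measured compounds shown here, the only measured step, a step that the two limits leave unreadable from compound 2 to compound 3, is unreadable for the same reason, so no measured step bears on the change to compound 4 `COC/C=C/c1ccc(CN(C(=O)C2CCCCC2)c2cccc(/C=C/C(=O)OC)c2)cc1`, which is 4-(3-methoxyprop-1-en-1-yl)phenyl in place of 2-bromophenyl on a saturated chain carbon bound to an amide-type nitrogen. Compound 4 is expected to land at 300 nM, between 60 nM and 2000 nM, because compound 1 gives 77 nM and shows that a number can be reached in this series. The step of an at least 3.3-fold lower number from compound 3 to compound 4 (0.52 log units; beyond the scatter) is therefore expected to be a gain, though its size is uncertain.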

Compound 4, half-maximal effective concentration: 233 nM
Compound 4: the middle estimate sits 1.3-fold (0.11 log units) above what was measured; measured number inside the range.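

In this assay, among the compounds shown here, a group other than the one in compound 1 also gives a readable number on a saturated chain carbon bound to an amide-type nitrogen, with an at least 4.2-fold lower number from compound 3 to compound 4 (0.63 log units; beyond the scatter) and an at least 4.2-fold lower number from compound 2 to compound 4 (0.63 log units; beyond the scatter). Both steps start from a limit, not a number: the limit of > 1000 nM in this assay, at which 2 of the 4 values shown sit. On the aromatic carbon, 3-methoxyprop-1-en-1-yl in place of 2,6-dimethoxyphenyl keeps a measurable value at a modest loss, with a 3.0-fold higher number from compound 1 to compound 4 (0.48 log units; beyond the scatter).

As far as these compounds go, whether the double bond or the methoxy matters more remains open. So does whether an amine or a carboxylic acid in place of that methoxy would keep a measurable value.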